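A few compounds are considered here, and "the series" means these few. Any claim that something is new, unique, unknown or untested is made for them only; others in the source may bear on it.

Within the data shown here, the two compounds measured so far in a functional assay on CHO cells for antagonist activity at adenosine receptor A2b (Homo sapiens), read by 33P incorporation, with a stated time of 20 min, in the presence of a further agent that is not named here (on this read-out lower numbers stand for stronger inhibition and higher numbers for weaker inhibition), both sit at the edge of what the assay can report. Compound 1, `Cc1ccc(C(=O)Nc2nc(Cl)c3cn(CC(C)(C)C)nc3n2)cc1`, gives > 10000 nM, which is a limit of the assay and not a number. Compound 2, `CCOC(=O)c1nc(NC(=O)c2ccc(C(F)(F)F)cc2)nc2nn(CC(C)(C)C)cc12`, gives > 20000 nM, likewise a limit rather than a measured number. Compound 2 therefore stands at the limit of > 20000 nM in this assay, at which 1 of the 2 values shown sits. The other value on hand sits at the limit of > 10000 nM in this assay, at which 1 of the 2 values shown sits. Neither compound shows an inhibition constant that can actually be placed on the scale.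

Compound 3, `CCOC(=O)c1nc(NC(=O)c2ccc(C)cc2)nc2nn(CC(C)(C)C)cc12`, differs from compound 2 in one place: methyl in place of trifluoromethyl on an aromatic carbon. Among the measured compounds shown here, no step between measured compounds is available to guide the size of this change. For the measured compounds named here, both compounds measured so far, carrying either a methyl or a trifluoromethyl on that ring, fall outside the reportable range of this assay, so no step beyond the scatter is expected, a step that the limit leaves unreadable from compound 2 to compound 3. Compound 3 is accordingly expected to give about 30000 nM, somewhere between 10000 nM and 100000 nM, and most likely to be reported once more only as a limit.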

Compound 3, inhibition constant: > 20000 nM
Compound 3: no number, only a limit; the forecaster's own chance of this, stated with the estimate: 85%; the middle value lies beyond the limit too.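

Compound 3 gives > 20000 nM, which is a limit of the assay and not a number. Among these compounds, compound 1 and compound 2 are also known only as limits, so no step from either of them to compound 3 can be read. The compounds shown leave open how strongly any of the three inhibits in this assay, and whether methyl in place of trifluoromethyl changes that at all.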